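The compounds below may be only part of what the source reports. "The series", "measured", "known", "first", "only" and "open" are said of these compounds alone.

Measured compounds in an ADME assay on cells (Hepatocyte, Homo sapiens) for pharmacokinetics, read by LC-MS, with a stated time of 90 min, tested at 1 uM; a higher number here means faster removal of the compound, a lower number slower removal:
Compound 1 `CN(C)c1ccc(Nc2c(NCCCCCC(=O)NO)c(=O)c2=O)cc1` gives a limit, < 5 uL/min.
Compound 2 `COc1ccc(Nc2c(NCCCCCC(=O)NO)c(=O)c2=O)cc1` gives a limit, < 4.7 uL/min.

Compound 1 stands only at a limit in this assay, and compound 2 likewise; a step that the two limits leave unreadable from compound 1 to compound 2 is therefore not readable in size, the two values sitting at the limit of < 5 uL/min in this assay, at which 1 of the 2 values shown sits, and (the limit of < 4.7 uL/min in this assay, at which 1 of the 2 values shown sits). Compound 3 `COc1cc(Nc2c(NCCCCCC(=O)NO)c(=O)c2=O)ccc1N(C)C` differs from compound 1 by methoxy in place of hydrogen on an aromatic carbon. Within the data shown here, no measured step bears directly on this change: the only measured step, a step that the two limits leave unreadable from compound 1 to compound 2, concerns a different replacement and its size is hidden by the limits. Nothing among the numbers gives a direction, so no step beyond the scatter is expected in this assay. Compound 3 is therefore expected to sit at about 4 uL/min, within 2 uL/min to 10 uL/min, which means an expected step that the limit leaves unreadable from compound 1 to compound 3, and most likely this assay again reports only a limit for it.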

Compound 3, intrinsic clearance in a liver preparation (reported as CLH), per the amount of preparation that the assay uses: < 5 uL/min
Compound 3 was reported as a limit; the forecaster's own chance of this, stated with the estimate: 70%; the middle value lies beyond the limit too.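

In this assay compound 3 gives only a limit, < 5 uL/min. Compound 1 also stands at a limit, so no step can be read between compound 1 and compound 3. The compounds shown leave open how fast each is actually removed in this assay, and whether methoxy in place of hydrogen on an aromatic carbon changes that at all.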